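The source may hold more compounds than are shown below. What is called first, only, known or untested is meant among the compounds shown, and "the series" means these compounds.

In an ADME assay on WI-38 cells (Homo sapiens) for antiproliferative activity, read by sulforhodamine B assay, with a stated time of 72 h (on this read-out lower numbers stand for stronger inhibition and higher numbers for weaker inhibition), compound 1 `CCCSc1ccc2c3c(cccc13)C1=NC(=O)C(C(=O)OCC)=C12` gives 9600 nM, the higher of the two numeric values in the series. Compound 3 `C=CCSc1ccc2c3c(cccc13)C1=NC(=O)C(C(=O)OCC)=C12` gives 4600 nM. The step between them is a 2.1-fold lower number from compound 1 to compound 3 (0.32 log units; beyond the scatter), a modest one, for vinyl in place of ethyl on a saturated chain carbon bound to a sulfur. Compound 2 `C=CCSc1ccc2c3c(cccc13)C1=NC(=O)C(C(=O)OCC(=O)SCCC)=C12` reads > 100000 nM, which is a limit of the assay and not a number.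

Compound 4 `CCCSc1ccc2c3c(cccc13)C1=NC(=O)C(C(=O)OCC(=O)OCC(F)(F)C(F)(F)F)=C12` differs from compound 1 by (2,2,3,3,3-pentafluoropropoxy)carbonyl in place of methyl on a saturated chain carbon bound to an oxygen next to a carbonyl group. The vinyl for ethyl step lies at another place and bears little on this change. The step that bears on it is an at least 21-fold lower number from compound 2 to compound 3 (1.33 log units; beyond the scatter), a large one that rests on a limit, for methyl in place of (propylsulfanyl)carbonyl at the same place. Read in reverse, that step links a carbonyl-bearing group on this carbon with much weaker inhibition. For the measured compounds named here, the group entering compound 4 is not the one in compound 2, so the transfer is only partial. A large step towards a higher number is therefore expected in this assay. The estimated step is a 6.3-fold higher number from compound 1 to compound 4 (0.80 log units; beyond the scatter). Compound 4 is expected at 60000 nM, with an estimated range of 15000 nM to 200000 nM.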

Compound 4, half-maximal inhibitory concentration: 58800 nM
Compound 4: the middle estimate sits 1.0-fold (0.01 log units) above what was measured; measured number inside the range.
By their numbers in this assay, from the lowest: compound 3; then compound 1; then compound 4. At a limit, above all of these: compound 2.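

Compound 2, with (propylsulfanyl)carbonyl on this carbon, gave only a limit and not a number: the limit of > 100000 nM in this assay, at which 1 of the 4 values shown sits. With (2,2,3,3,3-pentafluoropropoxy)carbonyl on the saturated chain carbon bound to an oxygen next to a carbonyl group, the change now has a measured size in this assay, as a 6.1-fold higher number from compound 1 to compound 4 (0.79 log units; beyond the scatter), and compound 4 gives 58800 nM as a number and not a limit. The earlier step at this place, an at least 21-fold lower number from compound 2 to compound 3 (1.33 log units; beyond the scatter), points the same way as the new one, with the methyl compound at the lower number in both pairs and neither pair going against this, although the two pairs carry different chains on the sulfur and the entering groups are different.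

Two groups on this carbon cannot show whether the higher numbers follow the carbonyl or the rest of the group, and a carboxylic acid or a plain methoxycarbonyl here would help to separate the two. On these data alone, it also remains open whether a 2.1-fold lower number from compound 1 to compound 3 (0.32 log units; beyond the scatter), seen with methyl on this carbon, carries over to compounds with (2,2,3,3,3-pentafluoropropoxy)carbonyl at this place.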